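Phenoxy for tert-butyl on a piperazine urea

A few compounds are considered here, and "the series" means these few. Any claim that something is new, unique, unknown or untested is made for them only; others in the source may bear on it.

Compound 1 `Cc1ccc(NC(=O)N2CCN(c3ncccc3C(F)(F)F)CC2)cc1` gives 556 nM in a functional assay on HEK293 cells for antagonist activity at transient receptor potential cation channel subfamily V member 1 (Rattus norvegicus); on this read-out lower numbers stand for stronger inhibition and higher numbers for weaker inhibition.
Compound 2 `CC(C)(C)c1ccc(NC(=O)N2CCN(c3ncccc3C(F)(F)F)CC2)cc1` gives 11.3 nM in this assay.

Compound 2 stands lowest of the two numbers in this assay; the only other, compound 1, lies above it by a 49-fold lower number from compound 1 to compound 2 (1.69 log units; beyond the scatter). Compound 3 `O=C(Nc1ccc(Oc2ccccc2)cc1)N1CCN(c2ncccc2C(F)(F)F)CC1` follows from compound 2 by phenoxy in place of tert-butyl on an aromatic carbon. Among the measured compounds shown here, the one measured step that bears on this place, the change a 49-fold lower number from compound 1 to compound 2 (1.69 log units; beyond the scatter), was large and went toward lower numbers as the group at this carbon grew. Phenoxy is larger still, so compound 3 is expected to keep a low number, with a step of a 1.8-fold higher number from compound 2 to compound 3 (0.25 log units; within the scatter) in this assay. The estimate for compound 3 is 20 nM, within 5 nM to 80 nM.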

Compound 3, half-maximal inhibitory concentration: 258 nM
Compound 3: the middle estimate sits 13-fold (1.11 log units) below what was measured, outside the stated range (above it).
By their numbers in this assay, from the lowest: compound 2; then compound 3; then compound 1.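

In this assay, group size alone does not set the number at this aromatic carbon: phenoxy, larger than tert-butyl, brings a 23-fold higher number from compound 2 to compound 3 (1.36 log units; beyond the scatter). Against methyl it retains only a 2.2-fold lower number from compound 1 to compound 3 (0.33 log units; beyond the scatter), so compound 3 goes against any trend toward lower numbers with growing group size. Nothing available accounts for the gap between phenoxy and tert-butyl.

The compounds shown leave open whether the low number of compound 2 needs a branched alkyl group, which isopropyl or cyclohexyl at this carbon would test. A methoxy group would help separate the effect of the oxygen from that of the added ring.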